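A Second Chlorine on the Piperazine Aryl Ring

This account rests on a few compounds, and the source may have more. Where it says the series, first, only, none or still open, it means among the compounds named here.

Of the compounds shown here, three share one core and have been tested in a functional assay on HL-60 cells (Homo sapiens) for inhibition, read by MTT assay, with a stated time of 72 h; a lower number here means a stronger inhibitor, a higher number a weaker inhibitor. Compound 1 `Cc1nc(-c2ccccc2)c(C(=O)N2CCN(c3cccc(Cl)c3)CC2)o1` gives 39.2 nM, the lowest of the two numbers reported; its nearest neighbour, compound 2 `CC(=O)Nc1cccc(-c2nc(C)oc2C(=O)N2CCN(c3cccc(Cl)c3)CC2)c1`, gives 208 nM. Compound 3 `COc1ccc(-c2nc(C)oc2C(=O)N2CCN(c3cccc(Cl)c3)CC2)cc1O` is recorded as "not active" (no number reported), with no number to place it. Among the compounds with values here, the one single-change step that is available, a 5.3-fold higher number from compound 1 to compound 2 (0.72 log units; beyond the scatter), comes from acetamido in place of hydrogen on an aromatic carbon of the phenyl ring that hangs off the core.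

Compound 4 `Cc1nc(-c2ccccc2)c(C(=O)N2CCN(c3ccc(Cl)c(Cl)c3)CC2)o1` differs from compound 1 in a different place, (chloro in place of hydrogen on an aromatic carbon), on the ring that sits on the piperazine rather than on the core. Within the data shown here, no measured pair touches this ring, so the step from compound 1 to compound 2 and the silence of compound 3 say nothing direct about it. With no precedent in either direction, the expected outcome in this assay is a step of a 1.1-fold lower number from compound 1 to compound 4 (0.05 log units; within the scatter), that is, no change beyond the scatter. Compound 4 is therefore estimated at 35 nM, within a range of 12 nM to 110 nM.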

Compound 4, half-maximal inhibitory concentration: 124 nM
Estimate against measurement, compound 4: 3.5-fold (0.55 log units) below; the measured number lies above the stated range.
By their numbers in this assay, from the lowest: compound 1; then compounds 4 and 2 (each within the scatter of the next).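

The ring on the piperazine does respond to change: going from 3-chlorophenyl to 3,4-dichlorophenyl, with the new chloro ortho to a chloro group and para to a large group, gives a 3.2-fold higher number from compound 1 to compound 4 (0.50 log units; beyond the scatter) in this assay. Within the data shown here, until now, the only measured single change lay on the phenyl ring of the core, where acetamido gave a 5.3-fold higher number from compound 1 to compound 2 (0.72 log units; beyond the scatter) and likewise made the inhibitor weaker. Both single changes on compound 1, one on each aryl ring, therefore raise the number, so compound 1 remains the best reference point among the compounds with a number, while compound 3 has none to test this against. No measurement here bears on what lies behind the new step.

From the compounds shown here alone, what stays open is whether any added group at this carbon raises the number or whether this is particular to chloro, a question that an amine or a carboxylic acid in the same place would help settle. Going by these compounds, it is also open how much the existing chloro group contributes: the informative partner for compound 1 would be the same structure with an unsubstituted phenyl on the piperazine.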